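The source may hold more compounds than are shown below. What is called first, only, known or untested is meant among the compounds shown, and "the series" means these compounds.

Compound 1, `CN(C)c1cccc(C(=O)N[C@H]2CCC[C@H](NC(=O)c3cccc(Cl)c3)C2)c1`, gives only a limit of > 10000 nM in a functional assay on HEK293 cells for antagonist activity at metabotropic glutamate receptor 5 (Homo sapiens), read by FLIPR and calcium flux; on this read-out lower numbers stand for stronger inhibition and higher numbers for weaker inhibition.
Compound 2, `O=C(NC1CCCC(NC(=O)c2cccc(Cl)c2)C1)c1cccc(Cl)c1`, gives 139 nM in this assay.
Compound 3, `CN(C(=O)c1cccc(Cl)c1)C1CCCC(NC(=O)c2cccc(Cl)c2)C1`, gives only a limit of > 10000 nM in this assay.

Compound 3 sits at the edge of what this assay can report: its value is a limit, not a number, and it shares that place with one other compound, as the limit of > 10000 nM in this assay, at which 2 of the 3 values shown sit, shows. Compound 2, which carries a hydrogen on both amide-type nitrogens, gives a number, so compound 3 cannot be placed relative to compound 1, only relative to compound 2.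

Compound 4, `CN(C(=O)c1cccc(Cl)c1)C1CCCC(N(C)C(=O)c2cccc(Cl)c2)C1`, carries the change (methyl in place of hydrogen on an amide-type nitrogen), so that both amide-type nitrogens now bear a methyl. Within the data shown here, the one measured step that bears on this is an at least 71-fold higher number from compound 2 to compound 3 (1.85 log units; beyond the scatter), a large loss when the first methyl went onto an amide-type nitrogen. With compound 3 already at the limit, the second methyl is not expected to bring the value back into the measurable range; the expected step that the limit leaves unreadable from compound 3 to compound 4 is one that keeps compound 4 at or past the limit. The estimate for compound 4 is therefore 30000 nM, with a range from 8000 nM to 200000 nM.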

Compound 4, half-maximal inhibitory concentration: > 10000 nM
Compound 4 ended at the assay's limit (the forecaster's own chance of this, stated with the estimate: 90%); the middle value does not contradict the limit.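

Compound 3 and compound 4 both give a limit and not a number, so the step between them cannot be read: the limit of > 10000 nM in this assay, at which 3 of the 4 values shown sit. The compounds shown leave open how far past that limit each of the two lies, and so whether the second methyl on an amide-type nitrogen changes the inhibition at all.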